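This account rests on a few compounds, and the source may have more. Where it says the series, first, only, none or still open, it means among the compounds named here.

In a functional assay on OVCAR-3 cells (Homo sapiens) for antiproliferative activity, read by MTT assay, with a stated time of 24 h (on this read-out higher numbers stand for weaker inhibition and lower numbers for stronger inhibition), compound 2 `Cc1cccc(NNC(=O)c2ccccc2NS(=O)(=O)c2cnc(O)nc2O)c1` gives > 20000 nM, which is a limit and not a number. On these data alone, the position of compound 2 is therefore known only from one side, and any step starting from it stays open.

The next compound, compound 4 `O=C(NNC(=O)c1ccccc1NS(=O)(=O)c1cnc(O)nc1O)c1ccccc1Cl`, differs from compound 2 by (2-chlorophenyl)carbonyl in place of 3-methylphenyl on an amine nitrogen.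

Two measured compounds offer the nearest comparison. In this assay compound 1 `O=C(NNc1ccccc1Cl)c1ccc(NS(=O)(=O)c2cnc(O)nc2O)cc1` gives 7230 nM and compound 3 `O=C(NNC(=O)c1ccccc1F)c1ccc(NS(=O)(=O)c2cnc(O)nc2O)cc1` gives 16000 nM. That pair gives a 2.2-fold higher number from compound 1 to compound 3 (0.34 log units; beyond the scatter), with (2-fluorophenyl)carbonyl in place of 2-chlorophenyl on an amine nitrogen. Going by the values given here, it is the only measured step of this kind, and it is modest. It also sits on the core of compound 1, which is not the core shared by compound 2 and compound 4, so it carries over only loosely.

On that single step, a small move towards a higher number is expected in this assay, and no gain in inhibition is expected. For compound 4 the estimated change is a step that the limit leaves unreadable from compound 2 to compound 4. Compound 4 is estimated at 25000 nM, with an expected range from 11000 nM to 60000 nM, and a report of a limit alone would be no surprise.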

Compound 4, half-maximal inhibitory concentration: 18200 nM
For compound 4 the middle estimate is 1.4-fold (0.14 log units) above the measured one, within the range that was stated.
By their numbers in this assay, from the lowest: compound 1; then compounds 3 and 4 (each within the scatter of the next). At a limit, above all of these: compound 2.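

On the core shared by compound 2 and compound 4, (2-chlorophenyl)carbonyl in place of 3-methylphenyl on the amine nitrogen brings the series its first number at this position in this assay because compound 2 itself stands only at the limit > 20000 nM and compound 4 does not: the limit of > 20000 nM in this assay, at which 1 of the 4 values shown sits. The change reads as an at least 1.0-fold lower number from compound 2 to compound 4 (0.04 log units; that floor lies within the scatter) and this is a floor, so the swap of an aryl group for an aroyl group is at least not shown to raise the number on this core, while the true size of the step stays unknown. Compound 4 thus gives this core a measured anchor for later steps at the amine nitrogen, which the limit of compound 2 could not provide.

On these data alone, how far compound 2 really lies from compound 4 remains open, and so does whether the carbonyl or the chlorinated ring of the entering group carries the result. An acetyl group or a plain benzoyl group on the same amine nitrogen would separate those two parts.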